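The source may hold more compounds than are shown below. What is called first, only, known or untested is meant among the compounds shown, and "the series" means these compounds.

In a toxicity assay on CCRF-CEM cells (Homo sapiens) for cytotoxicity (a higher number here means that more compound is tolerated, a lower number that less compound is tolerated), three compounds built on one shared core have been measured. Compound 1 `CN(C)c1cccc2c1nc(-c1c(F)cccc1F)n2Cc1c(F)cccc1F` reports > 100 uM, which is a limit of the assay and not a number. Compound 2 `N#Cc1cccc2c1nc(-c1c(F)cccc1F)n2Cc1c(F)cccc1F` gives 26.7 uM, and compound 3 `NCc1cccc2c1nc(-c1c(F)cccc1F)n2Cc1c(F)cccc1F` gives 49.3 uM. Compound 3 thus stands level with its nearest neighbour, since a 1.8-fold higher number from compound 2 to compound 3 (0.27 log units; within the scatter) is a step that stays within the scatter. The floor of an at least 2.0-fold lower number from compound 1 to compound 3 (0.30 log units; that floor lies within the scatter) also lies within the scatter, so the separation of these two is not established.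

Compound 4 `CC(=O)N(C)Cc1cccc2c1nc(-c1c(F)cccc1F)n2Cc1c(F)cccc1F` carries acetyl(methyl)amino in place of amino on a saturated chain carbon bound to an aromatic carbon. Among the compounds with values here, none of the measured steps makes this change. All three swap groups on an aromatic carbon, and they offer only a rough guide to size. Only an at least 3.7-fold lower number from compound 1 to compound 2 (0.57 log units; beyond the scatter) goes beyond the scatter, while a 1.8-fold higher number from compound 2 to compound 3 (0.27 log units; within the scatter), the step that introduced the aminomethyl group, does not. No step beyond the scatter is therefore expected in this assay, and no direction can be firmly assigned. The estimate is a 1.1-fold higher number from compound 3 to compound 4 (0.05 log units; within the scatter), an expected step within the scatter. For compound 4 the expected value is 55 uM, with an estimated range from 24 uM to 100 uM.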

Compound 4, half-maximal toxic concentration: 20.6 uM
Beside the measured number, compound 4's estimate is 2.7-fold (0.43 log units) above it; the measured number lies below the stated range.
By their numbers in this assay, from the lowest: compounds 4, 2 and 3 (each within the scatter of the next, the first and the last beyond it). At a limit, above all of these: compound 1.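

The earlier steps shown here all swapped groups on an aromatic carbon, whereas here a change on a saturated chain carbon bound to an aromatic carbon gives a 2.4-fold lower number from compound 3 to compound 4 (0.38 log units; beyond the scatter), so in this assay a replacement at this place can move the number past the scatter. The new group does not separate from the nitrile, however: a 1.3-fold lower number from compound 2 to compound 4 (0.11 log units; within the scatter), so the (acetyl(methyl)amino)methyl group and the nitrile stand level in this assay, and the gain in size from amino to acetyl(methyl)amino does not carry the number past what the nitrile already gives. The third step, an at least 4.8-fold lower number from compound 1 to compound 4 (0.68 log units; beyond the scatter), goes beyond the scatter, but it is only a floor, set by a limit of the assay and not a number: the limit of > 100 uM in this assay, at which 1 of the 4 values shown sits.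

The compounds shown do not separate the acetyl part of the new group from its methyl part, and an acetylamino or a methylamino group on the same carbon would tell these apart. From the compounds shown here alone, whether a carboxylic acid or a longer chain at this place would move the number in the same direction also stays open, and a single step beyond the scatter sets no pattern.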